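A few compounds are considered here, and "the series" means these few. Any claim that something is new, unique, unknown or untested is made for them only; others in the source may bear on it.

Measured so far in a functional assay on MDA-MB-231 cells (Homo sapiens) for cytotoxicity, read by MTT assay, with a stated time of 48 h; a lower number here means a stronger inhibitor, a higher number a weaker inhibitor:
compound 1 `O=C(/C=C/c1ccc2c(c1)B(O)OC2)c1cccnc1`: 11400 nM
compound 2 `O=C(/C=C/c1ccc2c(c1)B(O)OC2)c1ccc(Br)cc1`: 9500 nM

Compound 2 stands at the lower of the two numbers shown, but its only neighbour is compound 1, and the step of a 1.2-fold lower number from compound 1 to compound 2 (0.08 log units; within the scatter) lies within the scatter, so nothing is settled between them. Compound 3 `O=C(/C=C/c1ccc2c(c1)B(O)OC2)c1ccc(I)cc1` is not yet measured. It differs from compound 2 by iodo in place of bromo on an aromatic carbon. Going by the values given here, the one measured step exchanges the whole aryl group on the carbonyl carbon and does not separate a bromo from an iodo; no measured pair bears directly on this halogen exchange, and the series gives no ground for a shift in either direction. The expected step is therefore none beyond the scatter. The estimate for compound 3 in this assay is 8500 nM, within 4000 nM to 18000 nM. This estimate means a step of a 1.1-fold lower number from compound 2 to compound 3 (0.05 log units; within the scatter), expected to stay within the scatter.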

Compound 3, half-maximal inhibitory concentration: 14900 nM
Beside the measured number, compound 3's estimate is 1.8-fold (0.24 log units) below it; the range from low to high includes it.
By their numbers in this assay, from the lowest: compounds 2, 1 and 3 (each within the scatter of the next).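

In this assay the halogen exchange now has a direct reading: a 1.6-fold higher number from compound 2 to compound 3 (0.20 log units; within the scatter) stays within the scatter, so iodo and bromo are not separated at this position on the aromatic carbon. Exchanging the whole aryl group on the carbonyl carbon, read with iodo, gives a 1.3-fold higher number from compound 1 to compound 3 (0.12 log units; within the scatter) and is also within the scatter, so compound 1, compound 2 and compound 3 remain undistinguished. No measured evidence bears on this result.

The compounds shown leave open whether any group at this position can move the number beyond the scatter, for example an amine or a carboxylic acid in place of the halogen. They also leave open whether a change to the shared core, rather than to the aryl group on the carbonyl carbon, would separate the series.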